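This account rests on a few compounds, and the source may have more. Where it says the series, first, only, none or still open, it means among the compounds named here.

Measured compounds:
compound 1, `CCc1nc2nc(C)cc(Nc3cccc(Cl)c3)n2n1`: 86.7%
compound 2, `CCc1nc2nc(C)cc(Nc3ccc(C(F)(F)F)cc3)n2n1`: 87.5%

In an ADME assay on a cell-free system (plasma, Homo sapiens) for protein binding, compound 1 gives 86.7%, and compound 2 gives 87.5%. Compound 2 shows the smaller unbound fraction of the two, but its value and that of compound 1 lie within the usual scatter of this assay, so no order between them can be claimed. The step from compound 2 to compound 3, `CCOc1nc2nc(C)cc(Nc3ccc(C(F)(F)F)cc3)n2n1`, alters one group on the shared core: ethoxy in place of ethyl on an aromatic carbon. Within the data shown here, no measured pair shows a change of this kind, so the data give no direct guide to its effect in this assay. Compound 3 is expected to show a step of a 1.3-fold higher unbound fraction from compound 2 to compound 3 (0.11 log units; within the scatter), small and toward less binding, or none beyond the scatter. Compound 3 is therefore estimated at 84%, with a range from 74% to 91%.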

Compound 3, plasma protein binding: 92.4%
For compound 3 the middle estimate is 2.1-fold (0.32 log units) (unbound fraction) above the measured one; the whole stated range lies below it.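

In this assay, among these compounds, this is the only measured change at this position, the aromatic carbon of the five-membered aromatic ring with 3 nitrogen, and it gives a 1.6-fold lower unbound fraction from compound 2 to compound 3 (0.22 log units; within the scatter) with ethoxy in place of ethyl. Bringing in the ether oxygen at this carbon therefore produces no change in this assay that can be claimed, though one pair cannot speak for the position as a whole. Nothing available bears on what lies behind the two readings.

The compounds shown carry only ethyl or ethoxy at this carbon, so the effect of an amine, a carboxylic acid or a longer ether chain here remains open. Also open, going by these compounds, is whether the same exchange on compound 1 would give a step of similar size.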